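The source may hold more compounds than are shown below. What is called first, only, known or untested is meant among the compounds shown, and "the series" means these compounds.

Measured so far:

compound 1, `NCc1cccc(CN(C[C@H]2Cc3ccccc3CN2)[C@H]2CCCc3cccnc32)c1` — in a functional assay on cells for antagonist activity at C-X-C chemokine receptor type 4 (Homo sapiens), read by fluorescence and calcium flux, with stated times of 25 min and 90 s (a higher number here means a weaker inhibitor, a lower number a stronger inhibitor), compound 1 gives 292 nM

compound 2, `FC1(F)CCC(NC/C=C/CN(C[C@H]2Cc3ccccc3CN2)[C@H]2CCCc3cccnc32)CC1` — in this assay compound 2 gives 82.1 nM

Compound 2 has the lower of the two numbers, and the gap to compound 1 lies beyond the usual scatter, so compound 2 is the stronger inhibitor of the two. Compound 3, `C(=C/CN(C[C@H]1Cc2ccccc2CN1)[C@H]1CCCc2cccnc21)\CNC1CCOCC1`, keeps the shared core of compound 2 and changes only the ring on the amine nitrogen: oxan-4-yl in place of 4,4-difluorocyclohexyl on an amine nitrogen. For the measured compounds named here, no pair of measured compounds shows this kind of swap, so the expected size of the step rests on the change itself: one ring of similar size replaces another. The step from compound 2 to compound 3 in this assay is expected to be small, most likely toward a slightly higher number, and within the scatter: a 1.5-fold higher number from compound 2 to compound 3 (0.16 log units; within the scatter). For compound 3 the expected value is 120 nM, in the range 40 nM to 350 nM.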

Compound 3, half-maximal inhibitory concentration in the C-X-C chemokine receptor type 4 assay: 15.5 nM
Beside the measured number, compound 3's estimate is 7.7-fold (0.89 log units) above it, outside the stated range (below it).
By their numbers in the C-X-C chemokine receptor type 4 assay, from the lowest: compound 3; then compound 2; then compound 1.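

On this amine nitrogen the ring matters more than its similar size suggests: in the C-X-C chemokine receptor type 4 assay, oxan-4-yl in place of 4,4-difluorocyclohexyl gives a 5.3-fold lower number from compound 2 to compound 3 (0.72 log units; beyond the scatter), so exchanging one six-membered non-aromatic ring for another is enough to change the result. In the C-X-C chemokine receptor type 4 assay, the wider change, 3-((oxan-4-yl)amino)prop-1-en-1-yl in place of 3-(aminomethyl)phenyl on a saturated chain carbon bound to an amine nitrogen, gives a 19-fold lower number from compound 1 to compound 3 (1.28 log units; beyond the scatter). The gain in inhibition does not come with a loss in a physicochemical assay for permeability, using PAMPA, with a stated time of 4 h, at pH 7.4, tested at 100 uM (on this read-out higher numbers stand for higher permeability and lower numbers for lower permeability), where compound 2 gives 49 nm/s and compound 3 gives 434 nm/s and the same ring swap moves the number upward: the measured apparent permeability of compound 2, 49 nm/s, and of compound 3, 434 nm/s, an 8.9-fold higher number (0.95 log units; beyond the scatter)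

Going by these compounds, it remains open whether the ring oxygen or the loss of the two fluorines drives these steps, a question that a plain cyclohexyl ring could settle. On these data alone, it is also open whether oxan-4-yl would give a similar step on the 3-(aminomethyl)phenyl chain of compound 1.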